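Cytotoxicity on MT4 cells: swapping the aryl on the carbonyl

The source may report more compounds than this note shows. Statements on the series, on what has been measured and on what is new or still open speak of the compounds shown alone.

Measured compounds:
compound 1, `Cc1ccccc1C(=O)N(C(=S)OCCN1C(=O)c2ccccc2C1=O)c1ccc(Cl)cc1`, 21000 nM
compound 2, `O=C1c2ccccc2C(=O)N1CCOC(=S)N(C(=O)c1cccc([N+](=O)[O-])c1)c1ccc(Cl)cc1`, 18000 nM

In an ADME assay on MT4 cells (Homo sapiens) for cytotoxicity, read by MTT assay (on this read-out higher numbers stand for lower toxicity in this test and lower numbers for higher toxicity in this test), compound 2 gives 18000 nM, the lowest of the two numbers at hand, with compound 1 nearest at 21000 nM; the two lie within the scatter of each other, so neither can be called less toxic than the other.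

Compound 3, `Cc1cc(C(=O)N(C(=S)OCCN2C(=O)c3ccccc3C2=O)c2ccc(Cl)cc2)c(C)o1`, has not yet been measured in this assay. It differs from compound 2 in one place: 2,5-dimethylfuran-3-yl in place of 3-nitrophenyl on a carbonyl carbon. For the measured compounds named here, the only measured step that bears on a change at this carbonyl carbon is a 1.2-fold lower number from compound 1 to compound 2 (0.07 log units; within the scatter), which is within the scatter. Going by the values given here, that step exchanged one six-membered aromatic ring for another; the change to compound 3 brings in a five-membered aromatic ring with one hetero atom instead, so the single precedent is only a loose guide. On this basis no step beyond the scatter is expected for compound 3, and its estimated step is a 1.1-fold higher number from compound 2 to compound 3 (0.05 log units; within the scatter). The expected value for compound 3 is 20000 nM, estimated to fall between 8000 nM and 50000 nM.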

Compound 3, half-maximal cytotoxic concentration: 40000 nM
Estimate against measurement, compound 3: 2.0-fold (0.30 log units) below; the range from low to high includes it.
By their numbers in this assay, from the lowest: compounds 2, 1 and 3 (each within the scatter of the next, the first and the last beyond it).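

In this assay, for the compounds shown here, this change is the first at the carbonyl carbon to leave the scatter: 2,5-dimethylfuran-3-yl in place of 3-nitrophenyl gives (a 2.2-fold higher number from compound 2 to compound 3 (0.35 log units; beyond the scatter)), whereas the earlier exchange of one six-membered aromatic ring for another gave only (a 1.2-fold lower number from compound 1 to compound 2 (0.07 log units; within the scatter)). The same entering group in place of 2-methylphenyl gives (a 1.9-fold higher number from compound 1 to compound 3 (0.28 log units; within the scatter)), which stays within the scatter, so the shift towards lower toxicity in this test appears against only one of the two six-membered partners and is not a general result of bringing in the five-membered aromatic ring. Nothing at hand accounts for the difference between the two steps.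

The compounds shown leave open whether the modest step belongs to the departure of 3-nitrophenyl or to the arrival of 2,5-dimethylfuran-3-yl; a plain phenyl or an unsubstituted furan-3-yl on this carbonyl carbon would help to separate the two. Also open, as far as these compounds go, is how a non-aromatic group on that carbon, such as cyclohexyl or a longer chain bearing an amine, would read in this assay.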